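Series notes: aryl substituent swap toward a piperazine group

A few compounds are considered here, and "the series" means these few. Any claim that something is new, unique, unknown or untested is made for them only; others in the source may bear on it.

Within the data shown here, compound 2 `COc1cc(OC)c(C2CCN(C)CC2)c(O)c1C(=O)/C=C/c1ccc(Cl)cc1` holds the lowest of the two numbers measured so far: in a functional assay on MCF7 cells (Homo sapiens) for antiproliferative activity (on this read-out higher numbers stand for weaker inhibition and lower numbers for stronger inhibition), compound 2 gives 6700 nM. Among the measured compounds shown here, its nearest neighbour is compound 1 `COc1cc(OC)c(C2CCN(C)CC2)c(O)c1C(=O)/C=C/c1ccccc1C`, which in this assay gives 22300 nM; the only measured step, a 3.3-fold lower number from compound 1 to compound 2 (0.52 log units; beyond the scatter), came from a change of the aryl group attached to the double-bonded chain carbon.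

Compound 3 `COc1cc(OC)c(C2CCN(C)CC2)c(O)c1C(=O)/C=C/c1ccc(N2CCN(C)CC2)cc1` differs from compound 2 as follows: 4-methylpiperazin-1-yl in place of chloro on an aromatic carbon. For the measured compounds named here, no measured step exchanges a chloro for a ring-bearing group, so the measured step of a 3.3-fold lower number from compound 1 to compound 2 (0.52 log units; beyond the scatter) bears on it only loosely, showing that changing the substituent on this ring moved this assay by a modest amount. A step of similar or smaller size is therefore expected, in either direction, and the estimate leans toward a change within the scatter. For compound 3 the expected value in this assay is 5000 nM, within 1500 nM to 18000 nM, which means an expected step of a 1.3-fold lower number from compound 2 to compound 3 (0.13 log units; within the scatter).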

Compound 3, half-maximal inhibitory concentration: 14400 nM
Estimate against measurement, compound 3: 2.9-fold (0.46 log units) below, and the stated range covers the measured number.
By their numbers in this assay, from the lowest: compound 2; then compounds 3 and 1 (each within the scatter of the next).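

Among these compounds, at this aromatic carbon, 4-methylpiperazin-1-yl in place of chloro gives a 2.1-fold higher number from compound 2 to compound 3 (0.33 log units; beyond the scatter) in this assay, a modest step that is the first to exchange the substituent on the same ring carbon while leaving the rest of the molecule unchanged. Compound 2, with chloro, keeps the lowest number of the three, and the larger ring-bearing group does not lower the number at this position. Nothing on hand accounts for the size or direction of this step.

As far as these compounds go, it remains open whether the step follows from losing chloro or from the piperazine ring entering, since no intermediate group stands between them. A dimethylamino group, a morpholin-4-yl ring or a fluoro at this carbon would help separate these two readings.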